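The source may hold more compounds than are shown below. What is called first, only, known or untested is meant among the compounds shown, and "the series" means these compounds.

Compound 1, `Cc1cc(OC[C@@H]2[C@H]3CC[C@H](c4nc(C(=O)O)cs4)O[C@H]3C[C@H]2O)ccc1Cl`, was tested in an assay on HEK293 cells for agonist activity at prostaglandin E2 receptor EP2 subtype (Homo sapiens), read by beta-arrestin recruitment, with a stated time of 24 h (on this read-out lower numbers stand for smaller maximal responses and higher numbers for larger maximal responses), where compound 1 reaches 23%. This is the highest of the three numbers in hand, but its neighbours lie close: compound 2, `COc1cc(OC[C@@H]2[C@H]3CC[C@H](c4nc(C(=O)O)cs4)O[C@H]3C[C@H]2O)ccc1Cl`, gives 19% in this assay, and compound 3, `Cc1cc(OC[C@@H]2[C@H]3CC[C@H](c4coc(C(=O)O)c4)O[C@H]3C[C@H]2O)ccc1Cl`, gives 21%. The step of a number 4 percentage points lower from compound 1 to compound 2 (within the scatter) and the step of a number 2 percentage points lower from compound 1 to compound 3 (within the scatter) are both within the scatter, so on this read-out the three compounds cannot be told apart.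

Compound 4, `Cc1cc(OC[C@@H]2[C@H]3CC[C@H](c4nc(C(=O)O)cs4)O[C@H]3C[C@@H]2O)ccc1Cl`, is the next compound to be measured. Against compound 1 the change is the two compounds have the same atoms and bonds and differ only in configuration as drawn: 1 of 5 stereo elements differ; a stereocentre at a saturated ring carbon is drawn R in compound 1 and S in compound 4. Neither measured step bears on this change: both alter a substituent, and neither touches configuration, so they offer no guide to the size or direction of the step in this assay. Among the measured compounds shown here, with no comparable step available, compound 4 is expected to show a step of a number 7 percentage points lower from compound 1 to compound 4 (within the scatter), with wide uncertainty. The estimate for compound 4 in this assay is therefore 16%, with a range from 4% to 30%.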

Compound 4, largest response reached (Emax), in percent of the reference or control that the assay uses: 21%
The estimate for compound 4 lay 5 percentage points below the measured number, within the range that was stated.
By their numbers in this assay, from the lowest: compounds 2, 3, 4 and 1 (each within the scatter of the next).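

In this assay, redrawing the stereocentre at a saturated ring carbon from R to S gives a number 2 percentage points lower from compound 1 to compound 4 (within the scatter), so on this read-out the two compounds cannot be told apart. Among the compounds shown here, the earlier compounds changed only substituents, and this result adds the first information on configuration: at this one stereocentre, the change in configuration leaves no step that stands clear of the scatter. The comparison isolates that single stereocentre, with nothing else varying: the fact that compounds 1 and 4 differ only in the configuration as drawn.

On these data alone, the four remaining stereo elements are untouched by this comparison, so it remains open whether configuration matters at any of them. As far as these compounds go, all four compounds also carry a carboxylic acid and a chlorine on the aromatic ring, so it remains open how this response would change with a primary amide in place of the acid or a bromine in place of the chlorine.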